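Shifting the nitro group: an estimate for compound 3

A few compounds are considered here, and "the series" means these few. Any claim that something is new, unique, unknown or untested is made for them only; others in the source may bear on it.

- Compound 1 `COc1ccc(/C=C(\C#N)C(=O)N/N=C(\C)c2c(O)c3ccc(O)cc3oc2=O)cc1` gives 7850 nM
- Compound 2 `C/C(=N\NC(=O)/C(C#N)=C/c1ccc([N+](=O)[O-])cc1)c1c(O)c2ccc(O)cc2oc1=O` gives 8360 nM

Both numbers come from a functional assay on HeLa cells (Homo sapiens) for cytotoxicity, read by MTT assay, with a stated time of 24 h (on this read-out lower numbers stand for stronger inhibition and higher numbers for weaker inhibition), and are all there is to compare so far. Compound 2 (8360 nM) cannot be told apart from compound 1 on these numbers: the gap between them lies within the scatter.

Compound 3 (`C/C(=N\NC(=O)/C(C#N)=C/c1ccccc1[N+](=O)[O-])c1c(O)c2ccc(O)cc2oc1=O`) has the same atoms as compound 2, joined differently, with 2-nitrophenyl in place of 4-nitrophenyl on a double-bonded chain carbon bound to a double-bonded chain carbon.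

Among the compounds with values here, only one measured step offers any guide, and it is a different kind of change: a 1.1-fold higher number from compound 1 to compound 2 (0.03 log units; within the scatter) with nitro in place of methoxy on an aromatic carbon. Within the data shown here, no measured pair shows a nitro group changing its place, so the evidence is thin. With a 1.1-fold higher number from compound 1 to compound 2 (0.03 log units; within the scatter) as the only size available, no step beyond the scatter is expected in this assay and no direction can be favoured. The estimated step is small (a 1.0-fold lower number from compound 2 to compound 3 (0.02 log units; within the scatter)). For compound 3 the expected value is 8000 nM with an estimated range from 3500 nM to 18000 nM for repeated measurements.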

Compound 3, half-maximal inhibitory concentration: 10300 nM
For compound 3 the middle estimate is 1.3-fold (0.11 log units) below the measured one; measured number inside the range.
By their numbers in this assay, from the lowest: compounds 1, 2 and 3 (each within the scatter of the next).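

Moving the nitro group, with 2-nitrophenyl in place of 4-nitrophenyl on a double-bonded chain carbon bound to a double-bonded chain carbon, gives a 1.2-fold higher number from compound 2 to compound 3 (0.09 log units; within the scatter) in this assay. Within the data shown here, this is the first measured look at where the nitro group sits on the ring, and on these numbers its place cannot be told from the scatter of repeated measurements. Swapping 4-methoxyphenyl for 2-nitrophenyl at the same place gives a 1.3-fold higher number from compound 1 to compound 3 (0.12 log units; within the scatter), so all three aromatic groups tested here give numbers that cannot be separated, and nothing measured so far offers an explanation for this.

As far as these compounds go, the three compounds carry only a methoxy or a nitro group on that ring, so it remains open whether a quite different group there, such as an amine or a carboxylic acid, or a longer chain in place of the ring itself, would produce a step beyond the scatter. From the compounds shown here alone, all the numbers also come from a single cell line and a single stated time, so whether the same flat picture holds under other conditions is unknown.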